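The compounds below may be only part of what the source reports. "The series", "measured", "known", "first", "only" and "open" are said of these compounds alone.

Compound 1 `COc1cc(-c2ccnc3cc(-c4ccc(C)cc4)nn23)cc(OC)c1OC` gives 21 nM in a functional assay on HeLa cells (Homo sapiens) for inhibition, read by CCK-8 assay, with a stated time of 48 h (a higher number here means a weaker inhibitor, a lower number a stronger inhibitor), the lower of the two numbers recorded there. Compound 2 `COc1cc(-c2ccnc3cc(-c4ccc(C(C)=O)cc4)nn23)cc(OC)c1OC` gives 1810 nM; the step of an 86-fold higher number from compound 1 to compound 2 (1.94 log units; beyond the scatter) shows how sharply a change on this aryl group can move the number. Compound 3 `COc1ccc(-c2cc3nccc(-c4cc(OC)c(OC)c(OC)c4)n3n2)cc1F` differs from compound 1 by 3-fluoro-4-methoxyphenyl in place of 4-methylphenyl on an aromatic carbon. For the measured compounds named here, no measured step covers this exact exchange; the one recorded step only shows that this position tolerates change poorly. A modest weakening beyond the scatter is therefore expected, a 2.6-fold higher number from compound 1 to compound 3 (0.42 log units; beyond the scatter). Compound 3 is estimated at 55 nM, within 15 nM to 250 nM.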

Compound 3, half-maximal inhibitory concentration: 236 nM
Estimate against measurement, compound 3: 4.3-fold (0.63 log units) below; low and high end bracket the measured number.
By their numbers in this assay, from the lowest: compound 1; then compound 3; then compound 2.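

Replacing 4-methylphenyl with 3-fluoro-4-methoxyphenyl weakens inhibition clearly (an 11-fold higher number from compound 1 to compound 3 (1.05 log units; beyond the scatter)), yet the same group stands well clear of 4-acetylphenyl (a 7.7-fold lower number from compound 2 to compound 3 (0.88 log units; beyond the scatter)). This aromatic carbon therefore gives graded results rather than a single penalty for change: the three aryl groups fall at three separate levels, with 4-methylphenyl giving the lowest number. Nothing available explains why these groups differ. On these data alone, it remains open whether an amine or a carboxylic acid on this phenyl ring, or a longer alkyl chain in place of the methyl, would match compound 1.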